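Pyrrolidin-1-yl Replacing an Arylamino Group on a Shared Core

The source may report more compounds than this note shows. Statements on the series, on what has been measured and on what is new or still open speak of the compounds shown alone.

Measured compounds:
compound 1 `O=C1C=C(Nc2cccc(F)c2)C(=O)c2c1nc1n2[C@H]2OC[C@@H](O)[C@H]2OC1`: 2180 nM
compound 2 `COc1ccccc1NC1=CC(=O)c2nc3n(c2C1=O)[C@H]1OC[C@@H](O)[C@H]1OC3`: 1630 nM
compound 3 `COc1ccc(NC2=CC(=O)c3nc4n(c3C2=O)[C@H]2OC[C@@H](O)[C@H]2OC4)cc1`: 1680 nM

Of the compounds shown here, three sharing one core have been tested in a functional assay on MGC-803 cells (Homo sapiens) for inhibition, read by sulforhodamine B assay; on this read-out higher numbers stand for weaker inhibition and lower numbers for stronger inhibition. Compound 3 stands second highest of the three numbers. Its nearest neighbour is compound 2, with a 1.0-fold higher number from compound 2 to compound 3 (0.01 log units; within the scatter), and its furthest is compound 1, with a 1.3-fold lower number from compound 1 to compound 3 (0.11 log units; within the scatter). The remaining step, a 1.3-fold lower number from compound 1 to compound 2 (0.13 log units; within the scatter), is likewise within the scatter, so the three aryl groups on the amine nitrogen give no separation beyond noise.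

Compound 4 `O=C1C=C(N2CCCC2)C(=O)c2c1nc1n2[C@H]2OC[C@@H](O)[C@H]2OC1` differs from compound 3 by pyrrolidin-1-yl in place of (4-methoxyphenyl)amino on a double-bonded ring carbon. For the measured compounds named here, none of the measured steps touches this kind of change: each of them only exchanges one aryl group for another on the amine nitrogen, leaving the nitrogen-hydrogen in place. Going by the values given here, the data therefore give no direction for the step in this assay, and a wide range is warranted. Compound 4 is expected to give 2500 nM, within a range from 700 nM to 9000 nM. This estimate corresponds to an expected step of a 1.5-fold higher number from compound 3 to compound 4 (0.17 log units; within the scatter).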

Compound 4, half-maximal inhibitory concentration: > 16000 nM
Compound 4: only a limit was reported; the forecaster's own chance of this, stated with the estimate: 10%; middle value at least 6.4-fold (0.80 log units) from the limit.
By their numbers in this assay, from the lowest: compounds 2, 3 and 1 (each within the scatter of the next). At a limit, above all of these: compound 4.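

Compound 4 gives no number in this assay, only a limit: the limit of > 16000 nM in this assay, at which 1 of the 4 values shown sits.

The three aryl groups on the amine nitrogen stayed within the scatter of one another, yet pyrrolidin-1-yl in their place moves the read-out beyond the scatter towards weaker inhibition, with an at least 9.5-fold higher number from compound 3 to compound 4 (0.97 log units; beyond the scatter), an at least 9.8-fold higher number from compound 2 to compound 4 (0.99 log units; beyond the scatter) and an at least 7.3-fold higher number from compound 1 to compound 4 (0.86 log units; beyond the scatter). The double-bonded ring carbon therefore accepts an exchange of one aryl group for another without a measurable shift, while replacing the whole arylamino group costs inhibition in all three comparisons.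

On these data alone, what stays open is which part of the change carries this loss, the amine hydrogen or the six-membered aromatic ring, since both leave together. A cyclopentylamino group or a methyl(phenyl)amino group at this carbon would separate the two.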